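Adding a methyl group to compound 3

This account rests on a few compounds, and the source may have more. Where it says the series, first, only, none or still open, it means among the compounds named here.

In a functional assay on MCF7 cells (Homo sapiens) for antiproliferative activity, read by sulforhodamine B assay, with a stated time of 72 h (a higher number here means a weaker inhibitor, a lower number a stronger inhibitor), compound 1 (`COc1c(O)cc2occ(-c3csc4ccccc34)c(=O)c2c1O`) gives > 10000 nM as a limit of the assay, not a number. Compound 2 (`COc1c(OC(C)C)cc2ccc(-c3cc(=O)c4ccccc4o3)cc2c1OC(C)C`) gives > 10000 nM as a limit too. Within the data shown here, compound 3 (`O=C(/C=C/c1csc2ccccc12)c1ccccc1O`) stands at 6600 nM as the only actual number among the three. Compound 4 (`Cc1ccc(O)c(C(=O)/C=C/c2csc3ccccc23)c1`) has methyl in place of hydrogen on an aromatic carbon of compound 3 (methyl in place of hydrogen on an aromatic carbon), para to a hydroxy group. Among the measured compounds shown here, no measured pair shows this change, so the expectation rests on compound 3 at 6600 nM alone. In this assay no change beyond the usual scatter is expected, and the estimated 1.1-fold lower number from compound 3 to compound 4 (0.04 log units; within the scatter) has no firm direction. Compound 4 is estimated at 6000 nM with an expected range of 2500 nM to 10000 nM in all.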

Compound 4, half-maximal inhibitory concentration: 7800 nM
Compound 4: middle estimate off by 1.3-fold (0.11 log units), on the low side; measured number inside the range.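

In this assay, methyl in place of hydrogen on an aromatic carbon, para to a hydroxy group, gives a 1.2-fold higher number from compound 3 to compound 4 (0.07 log units; within the scatter). Among these compounds, this is the first measured pair of its kind, and it shows that this position tolerates a methyl group without a change beyond the usual scatter. Any real loss would soon run into the ceiling of the read-out: the limit of > 10000 nM in this assay, at which 2 of the 4 values shown sit.

The compounds shown leave open whether a longer chain, an amine or a carboxylic acid at this position would be tolerated as well. They also leave open whether methyl would behave the same way on the other carbons of this ring.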